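This account rests on a few compounds, and the source may have more. Where it says the series, first, only, none or still open, it means among the compounds named here.

Among the compounds with values here, compound 2, `COC(=O)C1=CN(C(C)C)C(=O)[C@@H]2C(CN3CCN(Cc4ccc(C(F)(F)F)cc4)CC3)=CC[C@H]12`, is one of two compounds so far tested in a functional assay on Cortical neurone cells (Rattus norvegicus, strain Sprague-Dawley), read by MTT assay, with stated times of 24 h and 2 h, tested at 1 uM; a higher number here means a stronger effect of the compound at the concentration tested, a lower number a weaker effect. In that assay compound 2 gives 71.6%. Within the data shown here, its only neighbour is compound 1, `COC(=O)C1=CN(C(C)C)C(=O)[C@@H]2C(CN3CCN(Cc4ccc([N+](=O)[O-])cc4)CC3)=CC[C@H]12`, which in this assay gives 74.3%; the gap between the two lies within the scatter, so neither can be set apart from the other. Among the measured compounds shown here, the single measured step, a number 2.7 percentage points lower from compound 1 to compound 2 (within the scatter), comes from trifluoromethyl in place of nitro on an aromatic carbon and shows that exchanging the group on that ring left the read-out essentially unchanged.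

Compound 3, `COC(=O)C1=CN(C(C)C)C(=O)[C@@H]2C(CN3CCN(Cc4cccc(C(F)(F)F)c4)CC3)=CC[C@H]12`, differs from compound 2 by 3-(trifluoromethyl)phenyl in place of 4-(trifluoromethyl)phenyl on a saturated chain carbon bound to an amine nitrogen in a ring. For the measured compounds named here, no measured step addresses moving the trifluoromethyl from one position of the ring to another; the only step available, from compound 1 to compound 2, swapped the group itself and stayed within the scatter. On that evidence the expected step is a number 0.4 percentage points higher from compound 2 to compound 3 (within the scatter), that is, none beyond the scatter. Compound 3 is therefore estimated to give 72% in this assay, expected to fall between 62% and 82%.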

Compound 3, a percentage reported as activity, at one concentration (the size of the read-out at that concentration, not a potency): 71.6%
The estimate for compound 3 lay 0.4 percentage points above the measured number; low and high end bracket the measured number.
By their numbers in this assay, from the lowest: compounds 2, 3 and 1 (each within the scatter of the next).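

In this assay, within the data shown here, placing the trifluoromethyl differently on the benzyl ring, with 3-(trifluoromethyl)phenyl in place of 4-(trifluoromethyl)phenyl, gives no change at the digits printed from compound 2 to compound 3 (within the scatter), which is the first measured test of where the group sits rather than which group it is, and the two placements cannot be told apart. The step that alters both the group and its placement, a number 2.7 percentage points lower from compound 1 to compound 3 (within the scatter), also stays within the scatter, so across these compounds neither the exchange of nitro for trifluoromethyl nor the shift of the trifluoromethyl separates one read-out from another. Nothing measured here explains why these three compounds cannot be told apart.

The compounds shown leave open whether this position tolerates any group at all, since a plain benzyl without a ring substituent, or a ring bearing an amine or a carboxylic acid, could still read differently from these three. They also leave open whether any of the compounds would have a stronger or weaker effect at another concentration, since each number is a read-out at a single concentration and a shared value there need not mean a shared concentration response.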